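The source may hold more compounds than are shown below. What is called first, only, known or untested is meant among the compounds shown, and "the series" means these compounds.

Two measured compounds share one core. Compound 1 `COc1cc(C2C(C#N)=C(N)Oc3c2ccc(O)c3N)cc(Br)c1OC` carries an amino group on an aromatic carbon of that core, and in a functional assay on T47D cells (Homo sapiens) for activation (on this read-out lower numbers stand for an effect already at smaller amounts and higher numbers for an effect only at larger amounts of compound), compound 1 gives 61000000 nM. Compound 2 `COc1cc(C2C(C#N)=C(N)Oc3cc(O)ccc32)cc(Br)c1OC` has a hydrogen in that place, and in this assay compound 2 gives 130000000 nM, the higher of the two numbers recorded. Among the compounds with values here, the single step between them, a 2.1-fold higher number from compound 1 to compound 2 (0.33 log units; beyond the scatter), is the only comparison available so far.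

The next compound, compound 3 `COc1cc(C2C(C#N)=C(N)Oc3c2ccc(O)c3O)cc(Br)c1OC`, arises from compound 2 by one change: hydroxy in place of hydrogen on an aromatic carbon. The step that bears on it is a 2.1-fold higher number from compound 1 to compound 2 (0.33 log units; beyond the scatter), in which an amino group in the same place went with the lower number. A hydroxy group also brings one hydrogen-bond donor, so compound 3 is expected to move back toward compound 1, whose value is 61000000 nM. The expected step is a 1.9-fold lower number from compound 2 to compound 3 (0.27 log units; within the scatter), a modest move downward in this assay. The estimate for compound 3 is 70000000 nM, with a range from 25000000 nM to 200000000 nM.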

Compound 3, half-maximal effective concentration: 589000000 nM
The estimate for compound 3 lay 8.4-fold (0.93 log units) below the measured number; measured number outside the range, above it.
By their numbers in this assay, from the lowest: compound 1; then compound 2; then compound 3.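

In this assay, hydroxy in place of hydrogen on this aromatic carbon gives a 4.5-fold higher number from compound 2 to compound 3 (0.66 log units; beyond the scatter), so a new group here does not have to move the number in the direction seen with amino. Hydroxy in place of amino gives a 9.7-fold higher number from compound 1 to compound 3 (0.98 log units; beyond the scatter), which puts hydrogen between the two groups: relative to hydrogen, amino goes with the lower number and hydroxy with the higher one, so what matters at this carbon is which group sits there, not merely whether hydrogen has been replaced. Nothing measured here explains why these two small groups part in this way.

Three groups on one carbon of one shared core cannot show whether amino or hydroxy is the unusual case, or where a methoxy group, a fluorine atom or a methylamino group would fall in this order. Going by these compounds, it also remains open whether the same order would hold with the neighbouring hydroxy group replaced by a methoxy group, since all three compounds carry that hydroxy group.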